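This account rests on a few compounds, and the source may have more. Where it says the series, first, only, none or still open, it means among the compounds named here.

Measured compounds:
Compound 1 `O=C(CC1Oc2cc(O)ccc2C=C1c1ccc(O)cc1)c1ccccc1`: 88000 nM
Compound 2 `Cc1ccc(C(=O)CC2Oc3cc(O)ccc3C=C2c2ccc(O)cc2)cc1`: 55000 nM

In a functional assay on MDA-MB-231 cells (Homo sapiens) for antiproliferative activity, read by spectrophotometry and resazurin assay, with a stated time of 72 h (on this read-out lower numbers stand for stronger inhibition and higher numbers for weaker inhibition), compound 2 gives 55000 nM, which lies within the scatter of compound 1 at 88000 nM, so the two cannot be told apart on these numbers. The next compound, compound 3 `O=C(CC1Oc2cc(O)ccc2C=C1c1ccc(O)cc1)c1cccc2ccccc12`, has not yet been measured. It differs from compound 2 at one place: naphthalen-1-yl in place of 4-methylphenyl on a carbonyl carbon. The shared core and its carbonyl stay as they are.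

Within the data shown here, only one measured step bears on this change: a 1.6-fold lower number from compound 1 to compound 2 (0.20 log units; within the scatter). That step is methyl in place of hydrogen on an aromatic carbon, a smaller alteration than the one now made, and it stays within the scatter. Among the measured compounds shown here, no measured compound yet carries naphthalen-1-yl, so the data give only weak guidance on direction. A slightly lower number is expected, but nothing firmly beyond the scatter. The estimated change is a 1.4-fold lower number from compound 2 to compound 3 (0.14 log units; within the scatter). For compound 3 the estimated value is 40000 nM, with an expected range from 15000 nM to 100000 nM.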

Compound 3, half-maximal inhibitory concentration: 106000 nM
Compound 3: middle estimate off by 2.7-fold (0.42 log units), on the low side; measured number above the stated range.
By their numbers in this assay, from the lowest: compounds 2, 1 and 3 (each within the scatter of the next).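

In this assay, among these compounds, naphthalen-1-yl is the first group on this carbonyl carbon with two six-membered aromatic rings of carbon only, and putting it in place of 4-methylphenyl gives a 1.9-fold higher number from compound 2 to compound 3 (0.28 log units; within the scatter), while putting it in place of phenyl gives a 1.2-fold higher number from compound 1 to compound 3 (0.08 log units; within the scatter). Both steps stay within the scatter, so going to 10 heavy atoms from the 7 of 4-methylphenyl adds a second ring without separating compound 3 from compound 1 or compound 2, and the three groups shown on this carbon cannot be told apart on these numbers. No evidence is available that would explain this result.

Every group shown on this carbonyl carbon is built on aromatic rings of carbon only, so it remains open whether pyridinyl, cyclohexyl, or a phenyl carrying an amine or a carboxylic acid would give a number beyond the scatter. Going by these compounds, it also remains open whether changes on the shared core would do so, as all three compounds keep that core unchanged.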